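A few compounds are considered here, and "the series" means these few. Any claim that something is new, unique, unknown or untested is made for them only; others in the source may bear on it.

Compound 1 `O=C(COc1ccc(C(=O)/C=C/c2ccccc2Cl)cc1)N[C@H]1CCOC1=O`: 17400 nM
Compound 2 `O=C1OCC[C@@H]1NC(=S)SCCOc1ccc([N+](=O)[O-])cc1`: > 64000 nM, a limit of the assay
Compound 3 `O=C1OCC[C@@H]1NC(=S)SCCOc1ccccc1Cc1ccccc1`: 39500 nM

In a functional assay on MCF7 cells (Homo sapiens) for antiproliferative activity, read by MTT assay, with a stated time of 72 h (on this read-out lower numbers stand for stronger inhibition and higher numbers for weaker inhibition), compound 1 gives 17400 nM, the lowest of the two numbers; compound 3 sits a step higher, beyond the usual scatter. Compound 2 reaches only (the limit of > 64000 nM in this assay, at which 1 of the 3 values shown sits). Compound 4 `O=C(COc1ccc(C(=O)/C=C/c2ccc(F)cc2)cc1)N[C@H]1CCOC1=O` differs from compound 1 by 4-fluorophenyl in place of 2-chlorophenyl on a double-bonded chain carbon bound to a double-bonded chain carbon. No measured pair among these compounds shows such an exchange on the aromatic ring, so the size of the step has no direct precedent here. The expectation is a small step, within the usual scatter, in no firm direction. On that basis compound 4 is estimated at 15000 nM, between 5000 nM and 45000 nM, a step of a 1.2-fold lower number from compound 1 to compound 4 (0.06 log units; within the scatter) that is expected rather than known.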

Compound 4, half-maximal inhibitory concentration: > 64000 nM
Compound 4: only a limit was reported; the forecaster's own chance of this, stated with the estimate: 10%; at least 4.2-fold (0.63 log units) between middle value and limit.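

In this assay, the exchange of 2-chlorophenyl for 4-fluorophenyl on a double-bonded chain carbon bound to a double-bonded chain carbon gives an at least 3.6-fold higher number from compound 1 to compound 4 (0.56 log units; beyond the scatter), so this place in the shared core is sensitive to the identity of its aromatic group. Compound 4 gives > 64000 nM, which is a limit of the assay and not a number, so the full size of the step cannot be read. That limit is now shared: the limit of > 64000 nM in this assay, at which 2 of the 4 values shown sit.

The halogen and its place on the ring change together here, so the compounds shown cannot separate the two. From the compounds shown here alone, whether 4-chlorophenyl or 2-fluorophenyl would stay close to compound 1 remains open.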